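The source may report more compounds than this note shows. Statements on the series, on what has been measured and on what is new or still open speak of the compounds shown alone.

Measured so far:
- compound 1 `CC[C@H](C)[C@H](N)CN(C(=O)[C@@H]1C[C@H]1C1CCCCC1)c1ccc(-c2ccccc2)cc1`: in a functional assay for agonist activity at G protein-coupled receptor 88 (Homo sapiens), read by HTRF and cAMP accumulation (a lower number here means that less compound is needed, a higher number that more compound is needed for the effect), compound 1 reaches only the assay limit of > 25000 nM, which is a bound and not a number.
- compound 2 `COc1ccccc1-c1ccc(N(C[C@@H](N)CC(C)C)C(=O)[C@@H]2C[C@H]2c2ccccc2)cc1`: in this assay compound 2 gives 3200 nM.
- compound 3 `CCOc1ccc(-c2ccc(N(C[C@@H](N)[C@@H](C)CC)C(=O)[C@@H]3C[C@H]3c3ccccc3)cc2)cc1`: in this assay compound 3 gives 90 nM.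

Among the two numbers available, compound 3 has the lowest; the nearest is compound 2, whose number is higher by a gap well beyond the scatter, and compound 1 contributes only a limit. Compound 4 `CC[C@H](C)[C@H](N)CN(C(=O)[C@@H]1C[C@H]1c1ccccc1)c1ccc(-c2ccc(N)cc2)cc1` differs from compound 3 in one place: amino in place of ethoxy on an aromatic carbon. Going by the values given here, no measured pair shows this change, so the step from compound 3 can only be estimated. Compound 4 is expected to need somewhat more compound, with a 3.3-fold higher number from compound 3 to compound 4 (0.52 log units; beyond the scatter) as the estimated step, though the change could lie within the scatter. For compound 4 the expected value in this assay is 300 nM, between 60 nM and 1500 nM.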

Compound 4, half-maximal effective concentration: 320 nM
The estimate for compound 4 lay 1.1-fold (0.03 log units) below the measured number; the range from low to high includes it.
By their numbers in this assay, from the lowest: compound 3; then compound 4; then compound 2. At a limit, above all of these: compound 1.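

In this assay, going by these compounds alone, replacing ethoxy with amino on this aromatic carbon gives a 3.6-fold higher number from compound 3 to compound 4 (0.55 log units; beyond the scatter), the first measured step at this position. The change is modest, and compound 4 still gives a real number, 320 nM, so this position accepts an amino group as well as an ethoxy group, at some cost. The swap removes two heavy atoms and adds a hydrogen-bond donor together, and nothing shown here accounts for the size of the step. Still open, from the compounds shown here alone, is how a hydroxyl, a dimethylamino or a longer alkoxy chain would behave here. Any of these would help separate the effect of group size from that of the donor.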